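Swapping the sulfonyl aryl group in a benzoxazole sulfonamide

The source may hold more compounds than are shown below. What is called first, only, known or untested is meant among the compounds shown, and "the series" means these compounds.

Three measured compounds share a benzoxazole sulfonamide core. Compound 1 `O=S(=O)(Nc1ccc(-c2nc3ccccc3o2)cc1)c1ccccc1Cl` was tested in an ADME assay on HEK293 cells (Homo sapiens) for cytotoxicity, read by resazurin assay, with a stated time of 48 h; on this read-out higher numbers stand for lower toxicity in this test and lower numbers for higher toxicity in this test. In this assay compound 1 gives only a limit, > 100000 nM, not a number (the limit of > 100000 nM in this assay, at which 1 of the 3 values shown sits). Compound 2 `O=S(=O)(Nc1ccc2oc(-c3ccccc3)nc2c1)c1ccccc1Cl` gives 73000 nM in this assay, and compound 3 `COc1ccccc1S(=O)(=O)Nc1ccc2oc(-c3ccccc3)nc2c1` gives 41000 nM.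

Going by the values given here, the one measured step that changes the aryl group on the sulfonyl sulfur is a 1.8-fold lower number from compound 2 to compound 3 (0.25 log units; within the scatter), a step within the scatter. It stays within the scatter, so it gives no sign that such a swap moves the read-out.

Compound 4 `CCc1ccc(S(=O)(=O)Nc2ccc(-c3nc4ccccc4o3)cc2)cc1` has not yet been measured in this assay. It differs from compound 1 by 4-ethylphenyl in place of 2-chlorophenyl on a sulfonyl sulfur. Among the compounds with values here, the only comparable measured step, from compound 2 to compound 3, is within the scatter, so no step beyond the scatter is expected here either. The step of a number no higher from compound 1 to compound 4 (the limit leaves the size open) is therefore expected to stay within the scatter. Compound 4 is expected to give about 100000 nM, with a range from 45000 nM to 250000 nM.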

Compound 4, half-maximal cytotoxic concentration: 82000 nM
Compound 4: middle estimate off by 1.2-fold (0.09 log units), on the high side; the range from low to high includes it.
By their numbers in this assay, from the lowest: compounds 3, 2 and 4 (each within the scatter of the next). At a limit, above all of these: compound 1.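

Placing 4-ethylphenyl in place of 2-chlorophenyl on the sulfonyl sulfur tests this position on the core of compound 1, whereas the earlier measured step used a different core and a methoxy for chloro change. In this assay, as far as these compounds go, the result is an at least 1.2-fold lower number from compound 1 to compound 4 (0.08 log units; that floor lies within the scatter), but this is only a floor, so the true size of the step remains unknown and may or may not lie beyond the scatter. Compound 1 stands at a limit and not at a number: the limit of > 100000 nM in this assay, at which 1 of the 4 values shown sits.

From the compounds shown here alone, it remains open whether a carboxylic acid or an amine on the aryl group, or a longer chain in place of the ethyl, would shift the read-out beyond the scatter. Going by these compounds, it is also open whether 4-ethylphenyl would give a similar result on the core of compound 2.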